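A few compounds are considered here, and "the series" means these few. Any claim that something is new, unique, unknown or untested is made for them only; others in the source may bear on it.

Among the measured compounds shown here, compound 1 `COc1nn2cc(-c3cc4c(OC)ccc(OC)c4o3)nc2s1` is the weaker of the two compounds measured so far in an assay for antagonist activity at proteinase-activated receptor 4 (Homo sapiens), with stated times of 5 min, 50 s and 15 min, in the presence of a further agent that is not named here; a lower number here means a stronger inhibitor, a higher number a weaker inhibitor: compound 1 gives 2100 nM, while compound 2 `COc1nn2cc(-c3cc4c(OC)cccc4o3)nc2s1` gives 350 nM. For the measured compounds named here, the single measured step, a 6.0-fold lower number from compound 1 to compound 2 (0.78 log units; beyond the scatter), removes one of the two methoxy groups on the shared core. Compound 3 `COc1nn2cc(-c3cc4cccc(OC)c4o3)nc2s1` removes the other one instead: hydrogen in place of methoxy on an aromatic carbon. Going by the values given here, only the step from compound 1 to compound 2 bears on this change, and it concerns a different methoxy group, so it is an imperfect guide; it does show that the core tolerates the loss of a methoxy group with a modest gain. A step of similar direction but smaller size, a 2.6-fold lower number from compound 1 to compound 3 (0.42 log units; beyond the scatter), is therefore expected for compound 3, with wide uncertainty. Compound 3 is estimated to give 800 nM in this assay, within a range from 250 nM to 2500 nM.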

Compound 3, half-maximal inhibitory concentration: 240 nM
Compound 3: middle estimate off by 3.3-fold (0.52 log units), on the high side, outside the stated range (below it).
By their numbers in this assay, from the lowest: compounds 3 and 2 (each within the scatter of the next); then compound 1.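

In this assay, replacing the methoxy group at this place, para to a methoxy group, with hydrogen gives an 8.8-fold lower number from compound 1 to compound 3 (0.94 log units; beyond the scatter), so compound 1 does not need this methoxy group for its activity. Together with a 6.0-fold lower number from compound 1 to compound 2 (0.78 log units; beyond the scatter), this shows that losing either methoxy group lowers the number beyond the scatter, and compound 2 and compound 3 lie within the scatter of each other. Nothing available here explains the effect of this change.

The compounds shown leave open how other groups at this place would compare with hydrogen and methoxy, for example fluorine, a hydroxyl group or a longer ethoxy chain. They also leave open what would happen if both methoxy groups were replaced by hydrogen in the same compound.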